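Swapping a Biaryl Arm for Bromine in a Liver-Cell Toxicity Test

The source may hold more compounds than are shown below. What is called first, only, known or untested is meant among the compounds shown, and "the series" means these compounds.

Of the compounds shown here, two have been measured so far. Compound 1 `CC1(Cc2ccccc2)CC(S(=O)(=O)c2cccc(C(F)(F)F)c2)=C(c2ccc(/C(N)=N\O)cc2)O1` and compound 2 `CC1(c2ccc(-c3ccccc3C#N)cc2)CC(S(=O)(=O)c2ccc(F)cc2)=C(c2ccc(/C(N)=N\O)cc2)O1` share a core but differ in several places at once. In an ADME assay on HepG2 cells (Homo sapiens) for cytotoxicity, read by MTT assay, with a stated time of 72 h (on this read-out lower numbers stand for higher toxicity in this test and higher numbers for lower toxicity in this test), compound 1 gives 33400 nM. In this assay compound 2 gives 58300 nM, the higher of the two numbers, though the gap to compound 1 is within the scatter, so the two cannot be ordered. Compound 3 `CC1(c2ccc(Br)cc2)CC(S(=O)(=O)c2ccc(F)cc2)=C(c2ccc(/C(N)=N\O)cc2)O1` is yet to be measured; it carries bromo in place of 2-cyanophenyl on an aromatic carbon. Among the measured compounds shown here, no measured pair shows what this exchange does. The step of a 1.2-fold lower number from compound 2 to compound 3 (0.07 log units; within the scatter) is expected to stay within the scatter. For compound 3 the estimated value is 50000 nM, with a range from 20000 nM to 120000 nM.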

Compound 3, half-maximal cytotoxic concentration: 19200 nM
Beside the measured number, compound 3's estimate is 2.6-fold (0.42 log units) above it; measured number below the stated range.
By their numbers in this assay, from the lowest: compounds 3, 1 and 2 (each within the scatter of the next, the first and the last beyond it).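

Putting bromo in place of 2-cyanophenyl on this aromatic carbon gives (a 3.0-fold lower number from compound 2 to compound 3 (0.48 log units; beyond the scatter)) in this assay. Among the compounds shown here, this is the first exchange at a single place in this set, and it shows that the group at this position can shift the result, with the smaller bromo compound reading as more toxic in this test. Nothing measured here accounts for the shift.

On these data alone, whether the loss of 2-cyanophenyl or the arrival of bromo drives the step stays open. Plain hydrogen, a methoxy group or an amine at this place would help tell these apart.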